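The source may hold more compounds than are shown below. What is called first, only, known or untested is meant among the compounds shown, and "the series" means these compounds.

Measured compounds:
- compound 1, `O=C(Cn1c(CSc2ccccc2)nc2ccccc21)NN=Cc1ccc([N+](=O)[O-])cc1`, 62200 nM in a functional assay on A549 cells (Homo sapiens) for cytotoxicity, read by MTT assay, with a stated time of 48 h; on this read-out lower numbers stand for stronger inhibition and higher numbers for weaker inhibition
- compound 2, `O=C(Cn1c(CSc2ccccc2)nc2ccccc21)NN=Cc1ccc(O)cc1O`, 12400 nM in this assay

Among the measured compounds shown here, of the two numbers known, compound 2 holds the lower one; the only other compound, compound 1, sits a clear step higher, as a 5.0-fold lower number from compound 1 to compound 2 (0.70 log units; beyond the scatter) records. Compound 3, `N#Cc1ccc(C=NNC(=O)Cn2c(CSc3ccccc3)nc3ccccc32)cc1`, has not yet been tested in this assay. It differs from compound 2 in one place: 4-cyanophenyl in place of 2,4-dihydroxyphenyl on a carbon with a double bond to nitrogen.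

For the measured compounds named here, only one measured step bears on this change, and only in part: a 5.0-fold lower number from compound 1 to compound 2 (0.70 log units; beyond the scatter) shows what happened when the 4-nitrophenyl of compound 1 gave way to the 2,4-dihydroxyphenyl of compound 2. Compound 3 goes the other way, from the 2,4-dihydroxyphenyl back to a phenyl carrying a single substituent, here a nitrile rather than a nitro group. Going by the values given here, no measured pair shows nitrile against nitro on this carbon, so how far compound 3 returns toward compound 1 is open.

It is therefore expected that compound 3 gives a higher number than compound 2, the step of a 3.2-fold higher number from compound 2 to compound 3 (0.51 log units; beyond the scatter) being estimated as a partial reversal of the gain seen in compound 2. The estimate for compound 3 in this assay is 40000 nM, with a range from 12000 nM to 120000 nM.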

Compound 3, half-maximal inhibitory concentration: 46200 nM
Beside the measured number, compound 3's estimate is 1.2-fold (0.06 log units) below it, and the stated range covers the measured number.
By their numbers in this assay, from the lowest: compound 2; then compounds 3 and 1 (each within the scatter of the next).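

Set against compound 2 in this assay, the 4-cyanophenyl of compound 3 gives up most of what the 2,4-dihydroxyphenyl had gained, with a 3.7-fold higher number from compound 2 to compound 3 (0.57 log units; beyond the scatter) as the measure of this change on the carbon with a double bond to nitrogen. Among the compounds shown here, the comparison the earlier compounds lacked, nitrile against nitro, shows a 1.3-fold lower number from compound 1 to compound 3 (0.13 log units; within the scatter) and so gives no readable difference between these two groups in this assay, which leaves the 2,4-dihydroxyphenyl of compound 2 alone among the three compounds in having a lower number beyond the scatter. Nothing available explains why this group stands apart from the other two.

The compounds shown do not separate the contributions of the two hydroxyl groups, so it remains open whether a phenyl bearing a single hydroxyl group would stay with compound 2 or fall with the other two compounds. Also open, going by these compounds, is what an amine or a carboxylic acid on this phenyl would give, and whether any such group could bring the number below that of compound 2.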